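The compounds below may be only part of what the source reports. "The series", "measured", "known", "first", "only" and "open" are said of these compounds alone.

Measured compounds:
- compound 1, `O=C(N[C@H](CSCc1ccccc1)C(=O)O)[C@@H](CS)Cc1ccc(Cl)cc1`: 3 nM
- compound 2, `O=C(N[C@H](CSCc1ccccc1)C(=O)O)[C@H](CS)Cc1ccccc1`: 32 nM

In an assay on isolated protein for inhibition of Neprilysin (Oryctolagus cuniculus) (on this read-out lower numbers stand for stronger inhibition and higher numbers for weaker inhibition), compound 2 gives 32 nM, the highest of the two numbers shown. Its nearest neighbour is compound 1, which in this assay gives 3 nM; the two differ in more than one place, so the gap between them is not read as a single step.

Compound 3, `O=C(N[C@H](CSCc1ccccc1)C(=O)O)[C@H](CS)Cc1ccc(Cl)cc1`, has not yet been measured. It differs from compound 2 in one place: chloro in place of hydrogen on an aromatic carbon. Within the data shown here, no measured pair shows this change alone, so its size is not known. In this assay compound 3 is expected to give 15 nM, within 4 nM to 60 nM, the step of a 2.1-fold lower number from compound 2 to compound 3 (0.33 log units; beyond the scatter) being an estimate.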

Compound 3, half-maximal inhibitory concentration: 147 nM
Compound 3: the middle estimate sits 9.8-fold (0.99 log units) below what was measured, outside the stated range (above it).
By their numbers in this assay, from the lowest: compound 1; then compound 2; then compound 3.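

With the stereocentre as drawn in compound 3, chloro in place of hydrogen on the aromatic ring does not strengthen inhibition: the change gives a 4.6-fold higher number from compound 2 to compound 3 (0.66 log units; beyond the scatter). Going from S to R at the stereocentre on the saturated chain carbon gives a 49-fold higher number from compound 1 to compound 3 (1.69 log units; beyond the scatter), a far larger loss of inhibition, and it can be assigned to configuration alone because nothing else separates the two structures: the fact that compounds 1 and 3 differ only in the configuration as drawn

From the compounds shown here alone, whether chloro has the same effect with the stereocentre drawn S remains open. So does the effect of a methoxy group or a fluorine atom in place of this chloro.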